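The compounds below may be only part of what the source reports. "The series", "measured", "known", "first", "only" and "open" are said of these compounds alone.

Among the measured compounds shown here, in a physicochemical assay for solubility, measured as kinetic solubility (a lower number here means a less soluble compound, a higher number a more soluble compound), compound 1 `Cc1ccc(Oc2cc(C(=O)Nc3cnc(C)cn3)cc3oc(C)cc23)cc1` gives 18000 nM, while compound 2 `Cc1cnc(NC(=O)c2cc(Oc3ccc(S(C)(=O)=O)cc3)c3cc(C)oc3c2)cn1` gives 3000 nM, the lower of the two numbers so far. For the measured compounds named here, the only measured step, a 6.0-fold lower number from compound 1 to compound 2 (0.78 log units; beyond the scatter), is methylsulfonyl in place of methyl on an aromatic carbon, and it lies beyond the scatter. Compound 3 `Cc1cnc(NC(=O)c2cc(Oc3ccc(C#N)cc3)c3cc(C)oc3c2)cn1` has not been measured. Its change from compound 2 is cyano in place of methylsulfonyl on an aromatic carbon, para to a large group: cyano in place of methylsulfonyl on an aromatic carbon. Going by the values given here, no measured compound carries cyano, so the evidence is thin. Among the compounds with values here, the step that introduced methylsulfonyl, a 6.0-fold lower number from compound 1 to compound 2 (0.78 log units; beyond the scatter), is the only guide, and the new change removes that group again. A partial return towards the higher number is therefore expected, and the expected modest step upward is a 2.2-fold higher number from compound 2 to compound 3 (0.34 log units; beyond the scatter). The estimate for compound 3 is 6500 nM, with an expected range from 2000 nM to 18000 nM.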

Compound 3, solubility: 2000 nM
The estimate for compound 3 lay 3.3-fold (0.51 log units) above the measured number; low and high end bracket the measured number.
By their numbers in this assay, from the lowest: compounds 3 and 2 (each within the scatter of the next); then compound 1.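

In this assay, cyano in place of methylsulfonyl on this aromatic carbon gives a 1.5-fold lower number from compound 2 to compound 3 (0.18 log units; within the scatter), so the two groups cannot be told apart here, although cyano carries fewer heavy atoms and no sulfur. Taking the methylsulfonyl group away therefore did not restore the higher number of compound 1. Measured against the methyl group, cyano gives a 9.0-fold lower number from compound 1 to compound 3 (0.95 log units; beyond the scatter) and methylsulfonyl gives a 6.0-fold lower number from compound 1 to compound 2 (0.78 log units; beyond the scatter), so among these compounds both groups sit on the lower side of methyl, and none goes against this.

As far as these compounds go, whether an amine, a carboxylic acid or a plain hydrogen at this position would fall with these two groups or nearer to methyl stays open. Nothing available here explains why cyano and methylsulfonyl end up so close.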